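The source may hold more compounds than are shown below. What is called first, only, known or untested is meant among the compounds shown, and "the series" means these compounds.

Working notes on the series.

Three analogues on the shared core have been measured in an assay for inhibition of acid-sensing ion channel 3 (Homo sapiens), read by patch clamp, tested at 1 uM; a lower number here means less inhibition, a higher number more inhibition at the concentration tested (going by the name of the read-out). Compound 1 `NC(N)=NC(=O)c1nc(Cl)c(NCc2ccc3ccccc3c2)nc1N` gives 27%. Compound 2 `CCCN(C)c1nc(N)c(C(=O)N=C(N)N)nc1Cl` gives 32%. Compound 3 `NC(N)=NC(=O)c1nc(Cl)c(N2CCCC2)nc1N` gives 12%, the lowest of the three numbers; its nearest neighbour is compound 1, and the gap to it lies beyond the scatter, as does the larger gap to compound 2.

One single-point step is known: a number 20 percentage points lower from compound 2 to compound 3 (beyond the scatter). Compound 4 `CSc1nc(N)c(C(=O)N=C(N)N)nc1Cl` has not yet been measured in this assay. It differs from compound 3 in one place: methylsulfanyl in place of pyrrolidin-1-yl on an aromatic carbon. Within the data shown here, no measured step swaps a ring amine for a methylsulfanyl group, so the step from compound 2 to compound 3 bears on it only loosely, showing that the group at this position moves the read-out by a modest amount. The methylsulfanyl group is smaller than either amine seen so far and carries no ring, so a return toward the level of compound 1 and compound 2 is possible, but equally the number may stay near compound 3.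

The expected step is therefore small and slightly upward, a number 8 percentage points higher from compound 3 to compound 4 (within the scatter). The estimate for compound 4 in this assay is 20%, within a range from 5% to 40%.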

Compound 4, a percentage reported as inhibition, at one concentration (the size of the read-out at that concentration, not a potency): 12%
Compound 4: middle estimate off by 8 percentage points, on the high side, and the stated range covers the measured number.
By their numbers in this assay, from the lowest: compounds 3 and 4 (each within the scatter of the next); then compounds 1 and 2 (each within the scatter of the next).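

In this assay, replacing the five-membered ring of pyrrolidin-1-yl with the two heavy atoms of methylsulfanyl gives no change at the digits printed from compound 3 to compound 4 (within the scatter), so neither the ring, the ring nitrogen, nor the larger size of pyrrolidin-1-yl is needed at this aromatic carbon for the read-out to stay at this level. Compound 3 alone could not separate these features, but the second drop, a number 20 percentage points lower from compound 2 to compound 4 (beyond the scatter), matches the earlier step in size with a group that has no ring and no nitrogen, so among these three groups, methyl(propyl)amino stands apart from the other two. No supporting data bear on what lies behind this, and the result stands as an observation only.

The compounds shown do not tell whether a longer sulfur-linked chain such as propylsulfanyl would restore the number seen with methyl(propyl)amino, or whether the propyl chain on nitrogen is what matters, as dimethylamino or a primary amine at this position could show. As far as these compounds go, a methoxy group at the same carbon also remains open, as does whether these single-concentration numbers reflect differences in potency.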